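Replacing a methoxy group by a methoxycarbonyl group

This account rests on a few compounds, and the source may have more. Where it says the series, first, only, none or still open, it means among the compounds named here.

Three compounds share one core and differ only in the aromatic group attached to a saturated ring carbon. Compound 1 `Cc1cccc(C2(CNC(=O)Nc3c(C(C)C)cccc3C(C)C)CCCC2)c1` gives 15 nM in an assay on microsomes for inhibition of acyl-CoA:cholesterol acyltransferase (Oryctolagus cuniculus); on this read-out lower numbers stand for stronger inhibition and higher numbers for weaker inhibition. Compound 2 `COc1ccc(C2(CNC(=O)Nc3c(C(C)C)cccc3C(C)C)CCCC2)cc1` gives 31 nM, and compound 3 `CC(C)c1cccc(C(C)C)c1NC(=O)NCC1(c2ccc(C(F)(F)F)cc2)CCCC1` gives 66 nM. Compound 2 therefore stands second highest of the three numbers, with a 2.1-fold higher number from compound 1 to compound 2 (0.32 log units; beyond the scatter) on one side and a 2.1-fold higher number from compound 2 to compound 3 (0.33 log units; beyond the scatter) on the other; the span from compound 1 to compound 3 is a 4.4-fold higher number from compound 1 to compound 3 (0.64 log units; beyond the scatter).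

The unmeasured compound 4 `COC(=O)c1ccc(C2(CNC(=O)Nc3c(C(C)C)cccc3C(C)C)CCCC2)cc1` differs from compound 2 by methoxycarbonyl in place of methoxy on an aromatic carbon. Among the compounds with values here, no measured step exchanges these two groups, so the only step that touches the same position is a 2.1-fold higher number from compound 2 to compound 3 (0.33 log units; beyond the scatter), where a different group took the place of methoxy on an aromatic carbon and the number rose modestly. Within the data shown here, both changes at this position so far have raised the number, though none of them involved a methoxycarbonyl group.

On that footing, a modest rise is expected: a 1.9-fold higher number from compound 2 to compound 4 (0.29 log units; within the scatter), so that compound 4 is estimated at 60 nM, within a range of 25 nM to 150 nM.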

Compound 4, half-maximal inhibitory concentration: 360 nM
Estimate against measurement, compound 4: 6.0-fold (0.78 log units) below; measured number outside the range, above it.
By their numbers in this assay, from the lowest: compound 1; then compound 2; then compound 3; then compound 4.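

In this assay, methoxycarbonyl in place of methoxy on this aromatic carbon, para to a large group, gives a 12-fold higher number from compound 2 to compound 4 (1.06 log units; beyond the scatter), a large step where the exchange of methoxy for trifluoromethyl had given only a 2.1-fold higher number from compound 2 to compound 3 (0.33 log units; beyond the scatter). The new group also separates clearly from trifluoromethyl, with a 5.5-fold higher number from compound 3 to compound 4 (0.74 log units; beyond the scatter), so the identity of the group at this position matters more than the first three compounds could show, and compound 4 now carries the highest number of the four, with its steps to all the others beyond the scatter. Measured from the lowest number in the set, the change reads a 24-fold higher number from compound 1 to compound 4 (1.38 log units; beyond the scatter), which extends a series of modest steps into a large one.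

Nothing among the data shown accounts for the size of this rise. From the compounds shown here alone, it remains open whether a carboxylic acid, a primary amide or an acetyl group at the same place would give a number near that of compound 4 or near that of compound 2, and so whether the whole methoxycarbonyl group or only part of it goes with the rise.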